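A few compounds are considered here, and "the series" means these few. Any claim that something is new, unique, unknown or untested is made for them only; others in the source may bear on it.

In a functional assay on MGC-803 cells (Homo sapiens) for inhibition, read by MTT assay, with a stated time of 72 h (on this read-out lower numbers stand for stronger inhibition and higher numbers for weaker inhibition), compound 1 `C#CCSc1nc(Nc2ccccc2)c2ccncc2n1` gives 16200 nM and compound 2 `C#CCSc1nc(Nc2ccccc2Cl)c2ccncc2n1` gives 27600 nM and these two values lie within the scatter of each other. Compound 3 `C#CCSc1nc(Nc2ccc(Cl)cc2)c2ccncc2n1` carries one change from compound 1 chloro in place of hydrogen on an aromatic carbon with chloro in place of hydrogen on an aromatic carbon, para to a large group. Going by the values given here, the only measured step that bears on it is the same replacement on another carbon of that ring, a 1.7-fold higher number from compound 1 to compound 2 (0.23 log units; within the scatter) which stayed within the scatter. No step beyond the scatter is therefore expected in this assay from this replacement. The estimated step is a 1.1-fold higher number from compound 1 to compound 3 (0.05 log units; within the scatter) and so is expected to stay within the scatter. For compound 3 the expected value is 18000 nM with an estimated range from 7000 nM to 42000 nM in this measurement.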

Compound 3, half-maximal inhibitory concentration: 16400 nM
Beside the measured number, compound 3's estimate is 1.1-fold (0.04 log units) above it, and the stated range covers the measured number.
By their numbers in this assay, from the lowest: compounds 1, 3 and 2 (each within the scatter of the next).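

In this assay the change from phenyl to 4-chlorophenyl, with chloro para to a large group, gives a 1.0-fold higher number from compound 1 to compound 3 (0.01 log units; within the scatter) and so brings no step beyond the scatter at this carbon. Placing 4-chlorophenyl in place of 2-chlorophenyl gives a 1.7-fold lower number from compound 2 to compound 3 (0.23 log units; within the scatter) and so the two chloro placements cannot be told apart in this measurement. No supporting evidence bears on this result. As far as these compounds go, whether an amine or a carboxylic acid at this carbon would give a step beyond the scatter stays open. So does whether any group on this ring moves the number at all.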